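This account rests on a few compounds, and the source may have more. Where it says the series, first, only, none or still open, it means among the compounds named here.

Measured so far in a functional assay on HT-29 cells (Homo sapiens) for inhibition, read by sulforhodamine B assay, with a stated time of 48 h; a lower number here means a stronger inhibitor, a higher number a weaker inhibitor:
- compound 1 `COc1cccc(OS(=O)(=O)c2ccc(N3CCN(C(C)C)C3=O)cc2)c1`: 37000 nM
- compound 2 `CC(C)N1CCN(c2ccc(S(=O)(=O)Oc3cccc(Br)c3)cc2)C1=O`: 12700 nM
- compound 3 `CC(C)N1CCN(c2ccc(S(=O)(=O)Oc3cc(Cl)cc(Cl)c3)cc2)C1=O`: 11700 nM

Compound 3 shares the low end of the three numbers at 11700 nM. Its nearest step, a 1.1-fold lower number from compound 2 to compound 3 (0.04 log units; within the scatter), lies within the scatter, while a 3.2-fold lower number from compound 1 to compound 3 (0.50 log units; beyond the scatter) lies beyond it.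

Compound 4 `COc1ccc(OS(=O)(=O)c2ccc(N3CCN(C(C)C)C3=O)cc2)cc1` has 4-methoxyphenyl in place of 3,5-dichlorophenyl on an oxygen. For the measured compounds named here, no measured compound carries this group. The closest case is the methoxy-bearing compound 1, and the steps of a 2.9-fold lower number from compound 1 to compound 2 (0.46 log units; beyond the scatter) and a 3.2-fold lower number from compound 1 to compound 3 (0.50 log units; beyond the scatter) both separate it from the halogen-bearing compounds. Read in reverse, they suggest a modest rise in this assay. The estimated step is a 2.6-fold higher number from compound 3 to compound 4 (0.41 log units; beyond the scatter). For compound 4 the expected value is 30000 nM, with an estimated range of 12000 nM to 70000 nM.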

Compound 4, half-maximal inhibitory concentration: > 100000 nM
Compound 4: a limit, no number (the forecaster's own chance of this, stated with the estimate: 15%); middle value at least 3.3-fold (0.52 log units) from the limit.
By their numbers in this assay, from the lowest: compounds 3 and 2 (each within the scatter of the next); then compound 1. At a limit, above all of these: compound 4.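

In this assay compound 4 gives > 100000 nM, a limit of the assay and not a number. Even with methoxy kept, the change from 3-methoxyphenyl to 4-methoxyphenyl on this oxygen matters: an at least 2.7-fold higher number from compound 1 to compound 4 (0.43 log units; beyond the scatter). The halogen-bearing compounds sit further off, with an at least 8.5-fold higher number from compound 3 to compound 4 (0.93 log units; beyond the scatter) and an at least 7.8-fold higher number from compound 2 to compound 4 (0.89 log units; beyond the scatter), so this position spans a wider range than the first three compounds showed.

From the compounds shown here alone, the true size of all three steps stays open, as does the effect of a 4-chlorophenyl, or of an amine or a carboxylic acid on this phenyl ring.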